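Series notes: methoxy to chloro, compound 2 to compound 4

The source may hold more compounds than are shown below. What is called first, only, known or untested is meant among the compounds shown, and "the series" means these compounds.

Measured so far:
compound 1 `CCCCC(=O)N1N=C(c2cc(OC)ccc2N)SC1(C)C` — 101%
compound 2 `COc1ccc(N)c(C2=NN(C(=O)C3CCC3)C(C)(C)S2)c1` — 57.8%
compound 3 `COc1ccc(N)c(C2=NN(C(=O)c3ccccc3)C(C)(C)S2)c1` — 0%

In an assay on isolated protein for inhibition of Nitric oxide synthase, inducible (Homo sapiens), read by scintillation counting, with a stated time of 30 min, tested at 50 uM (a lower number here means less inhibition, a higher number more inhibition at the concentration tested (going by the name of the read-out)), compound 2 stands second highest of the three numbers: a number 43.2 percentage points lower from compound 1 to compound 2 (beyond the scatter) and a number 57.8 percentage points lower from compound 2 to compound 3 (beyond the scatter), both beyond the scatter, as is a number 101 percentage points lower from compound 1 to compound 3 (beyond the scatter). Every measured step changes the group on the carbonyl carbon and nothing else.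

Compound 4 `CC1(C)SC(c2cc(Cl)ccc2N)=NN1C(=O)C1CCC1` differs from compound 2 in one place: chloro in place of methoxy on an aromatic carbon. Within the data shown here, no measured step touches this position, so none of the three steps bears on the change; the three compounds share the methoxy group unchanged. With no evidence either way, the expected step in this assay is none beyond the scatter, but with a wide range. Compound 4 is therefore estimated at 55%, between 20% and 90%. For compound 4 the expected step is a number 2.8 percentage points lower from compound 2 to compound 4 (within the scatter).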

Compound 4, a percentage reported as inhibition, at one concentration (the size of the read-out at that concentration, not a potency): -4.65%
Compound 4: middle estimate off by 59.7 percentage points, on the high side; measured number below the stated range.
By their numbers in this assay, from the lowest: compounds 4 and 3 (each within the scatter of the next); then compound 2; then compound 1.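

In this assay, the position para to the amino group proves sensitive: chloro in place of methoxy gives a number 62.5 percentage points lower from compound 2 to compound 4 (beyond the scatter), so inhibition at the tested concentration depends on this substituent as well as on the group on the carbonyl carbon. Nothing available accounts for the drop.

Open, on these data alone, is whether the drop reflects the loss of methoxy or the arrival of chloro, which a hydroxy or ethoxy group at this position could help separate. Also open, as far as these compounds go, is whether the same change would hold with butyl on the carbonyl carbon.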